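This account rests on a few compounds, and the source may have more. Where it says the series, first, only, none or still open, it means among the compounds named here.

Measured compounds:
compound 1, `CC(C)c1cccc(C(C)C)c1NC(=O)NS(=O)(=O)N(C)C`, 3900 nM
compound 2, `CC(C)c1cccc(C(C)C)c1NC(=O)NS(=O)(=O)N(Cc1ccccc1)Cc1ccccc1`, 2200 nM

Of the compounds shown here, two sharing the same core have been measured in an assay on liver for inhibition of sterol O-acyltransferase 1 (Rattus norvegicus), using microsomes; a lower number here means a stronger inhibitor, a higher number a weaker inhibitor. Compound 1, with its dimethylamino group on the sulfonyl sulfur, gives 3900 nM in this assay, the higher of the two numbers. Compound 2 gives 2200 nM in this assay, and the gap between compound 2 and compound 1 lies within the scatter, so the two values show no difference that can be relied upon.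

The next compound, compound 3, `CCCCCCOS(=O)(=O)NC(=O)Nc1c(C(C)C)cccc1C(C)C`, has not yet been measured in this assay. It differs from compound 1 in one place: hexyloxy in place of dimethylamino on a sulfonyl sulfur. Within the data shown here, no step between measured compounds speaks to this change, so the expectation can rest only on the two values shown, which themselves do not separate. On that basis a small step is expected, if any, and the estimated step from compound 1 to compound 3 in this assay is a 2.0-fold lower number from compound 1 to compound 3 (0.29 log units; within the scatter), toward a lower number. Compound 3 is therefore expected to give about 2000 nM in this assay, within a range from 500 nM to 8000 nM.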

Compound 3, half-maximal inhibitory concentration: 27000 nM
Compound 3: middle estimate off by 14-fold (1.13 log units), on the low side; the whole stated range lies below it.
By their numbers in this assay, from the lowest: compounds 2 and 1 (each within the scatter of the next); then compound 3.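

Placing hexyloxy in place of dimethylamino on a sulfonyl sulfur gives a 6.9-fold higher number from compound 1 to compound 3 (0.84 log units; beyond the scatter) in this assay and shows that this position does not accept every change equally. The two earlier compounds, both with a nitrogen on the sulfur, had values within the scatter of each other, so they gave no sign that a change here could shift the number beyond the scatter. This one step, however, changes two things together, the atom bound to the sulfur and the size of the group, from 3 heavy atoms in dimethylamino to 7 in hexyloxy, and nothing measured in this set explains the step or shows which of the two matters.

The compounds shown leave open whether the oxygen or the six-carbon chain goes with the higher number, a question that a hexylamino group on the same sulfur or a shorter methoxy group could help to separate. Among these compounds, they also leave open how other oxygen-linked groups, such as benzyloxy, would compare with the dibenzylamino group of compound 2, since hexyloxy is the only such group here.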